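Series notes: from compound 1 to compound 4 in cytotoxicity

The compounds below may be only part of what the source reports. "The series", "measured", "known", "first", "only" and "open" are said of these compounds alone.

Three compounds of the shared core have been run in an ADME assay on Vero cells (Chlorocebus sabaeus) for cytotoxicity, read by MTT assay, with a stated time of 72 h; on this read-out lower numbers stand for higher toxicity in this test and higher numbers for lower toxicity in this test. Compound 1 `O=C(/C=C/c1ccc(O)cc1)Nc1nnc(-c2ccccc2)[nH]1` gives 1850000 nM and stands highest of the three, with compound 3 `O=C(/C=C/c1ccc2c(c1)COC2)Nc1nnc(-c2ccccc2)[nH]1` at 1820000 nM closest and compound 2 `O=C(/C=C/c1ccc([N+](=O)[O-])s1)Nc1nnc(-c2ccccc2)[nH]1` at 1670000 nM furthest; all three numbers lie within the scatter of one another, so no order among them can be read. Among the compounds with values here, the single step between compounds that differ in one place, a 1.1-fold lower number from compound 1 to compound 2 (0.04 log units; within the scatter), is likewise within the scatter; the series so far shows no movement in this assay beyond its noise.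

Compound 4 `C=C(C)COc1ccc(/C=C/C(=O)Nc2nnc(-c3ccccc3)[nH]2)cc1` differs from compound 1 in one place: 2-methylprop-2-en-1-yl in place of hydrogen on an oxygen on an aromatic ring. Within the data shown here, no measured step bears directly on this change. Among the measured compounds shown here, the only step available exchanges the aromatic group on the chain, not a substituent on the oxygen, and it was flat. With all three numbers clustered and that step within the scatter, no shift beyond the scatter is expected in this assay. Compound 4 is therefore expected at 1700000 nM, with a range from 900000 nM to 3200000 nM. The step this estimate implies, a 1.1-fold lower number from compound 1 to compound 4 (0.04 log units; within the scatter), is expected to stay within the scatter.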

Compound 4, half-maximal cytotoxic concentration: 1420000 nM
Estimate against measurement, compound 4: 1.2-fold (0.08 log units) above; measured number inside the range.
By their numbers in this assay, from the lowest: compounds 4, 2, 3 and 1 (each within the scatter of the next).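

Replacing hydroxy with (2-methylprop-2-en-1-yl)oxy gives a step in this assay (a 1.3-fold lower number from compound 1 to compound 4 (0.11 log units; within the scatter)) that leaves compound 1 and compound 4 indistinguishable. The earlier compounds shown here varied only the aromatic group on the chain, whereas this pair shows that, at this oxygen on an aromatic ring, removing the hydrogen and adding 2-methylprop-2-en-1-yl with its 4 heavy atoms produces no readable difference in this read-out. Nothing available accounts for this result or shows what the hydrogen or the added group contributes.

Still open, from the compounds shown here alone, is whether an amine or a carboxylic acid carried on this oxygen would stay within the scatter in this assay. Going by these compounds, a longer chain in this place also remains open, as does whether a saturated chain would read like 2-methylprop-2-en-1-yl.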